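Cell Tolerance of Sulfonamides: From Compound 3 to Compound 4

The compounds below may be only part of what the source reports. "The series", "measured", "known", "first", "only" and "open" are said of these compounds alone.

Compound 1, `Cc1ccccc1S(=O)(=O)Nc1ccc(-c2nc3ccccc3o2)cc1`: in an ADME assay on HEK293 cells (Homo sapiens) for cytotoxicity, read by resazurin assay, with a stated time of 48 h (a lower number here means that less compound is tolerated, a higher number that more compound is tolerated), compound 1 gives > 100000 nM, which is a limit of the assay and not a number.
Compound 2, `O=S(=O)(Nc1ccc(-c2nc3ccccc3o2)cc1)c1ccc(Cl)s1`: compound 2 gives > 100000 nM, again a limit of the assay.
Compound 3, `CCc1ccc(S(=O)(=O)Nc2ccc(-c3nc4ccccc4o3)cc2)cc1`: compound 3 gives 82000 nM.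

Within the data shown here, compound 3 therefore stands as the only plain number among the three; the other two values are limits. The unmeasured compound 4, `COc1ccccc1S(=O)(=O)Nc1ccc(-c2nc3ccccc3o2)cc1`, differs from compound 3 in one place: 2-methoxyphenyl in place of 4-ethylphenyl on a sulfonyl sulfur.

Two measured steps lead to compound 3 and bear on this change. The step of an at least 1.2-fold lower number from compound 1 to compound 3 (0.08 log units; that floor lies within the scatter) and the step of an at least 1.2-fold lower number from compound 2 to compound 3 (0.08 log units; that floor lies within the scatter) both have floors within the usual scatter, and the step that the two limits leave unreadable from compound 1 to compound 2 cannot be read at all. Because the limit of > 100000 nM in this assay, at which 2 of the 3 values shown sit, holds two of the three values, the spread between these compounds is small or invisible. No step beyond the scatter is therefore expected in this assay for compound 4; the expected step is a 1.1-fold higher number from compound 3 to compound 4 (0.04 log units; within the scatter). Compound 4 is estimated to give 90000 nM, within a range from 40000 nM to 200000 nM.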

Compound 4, half-maximal cytotoxic concentration: > 100000 nM
Compound 4: only a limit was reported; the forecaster's own chance of this, stated with the estimate: 45%; at least 1.1-fold (0.04 log units) between middle value and limit.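

The exchange of 4-ethylphenyl for 2-methoxyphenyl on a sulfonyl sulfur, which keeps the count of heavy atoms and adds one hydrogen-bond acceptor, gives an at least 1.2-fold higher number from compound 3 to compound 4 (0.08 log units; that floor lies within the scatter) in this assay. Going by these compounds, the value of compound 4 is a limit of the assay and not a number, so the true size of this step stays unknown, and the steps from compound 1 and from compound 2 to compound 4 cannot be read at all. Compound 3 remains the only compound with a plain number, and most readings now sit at one point: the limit of > 100000 nM in this assay, at which 3 of the 4 values shown sit.

On these data alone, all four compounds carry an aromatic ring on the sulfonyl sulfur, so it remains open whether an amine, a carboxylic acid or a plain alkyl chain in that place would give a step beyond the scatter. As far as these compounds go, the true numbers behind the limits of compound 1, compound 2 and compound 4 also stay open.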